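The source may hold more compounds than are shown below. What is called first, only, known or untested is meant among the compounds shown, and "the series" means these compounds.

The compounds share one core and differ in the group on a six-membered aromatic ring of carbon only. Compound 1 `CC(C)CN1C(=O)/C(=C/c2ccccc2C(F)(F)F)S/C1=N\c1ccccc1` carries a trifluoromethyl group on that ring; in an ADME assay on HepG2 cells (Homo sapiens) for cytotoxicity, read by MTT assay, with a stated time of 48 h (on this read-out lower numbers stand for stronger inhibition and higher numbers for weaker inhibition), compound 1 has "not determined" (no result reported). Compound 2 `CC(C)CN1C(=O)/C(=C/c2ccc([N+](=O)[O-])cc2)S/C1=N\c1ccccc1` carries a nitro group at the same place. In this assay compound 2 reaches only a limit, > 100000 nM, and not a number. Among the measured compounds shown here, this puts compound 2 at the limit of > 100000 nM in this assay, at which 1 of the 2 values shown sits, so the measured values offer no step from which a change could be judged. Compound 3 `CCc1ccc(/C=C2\S/C(=N\c3ccccc3)N(CC(C)C)C2=O)cc1` differs from compound 2 by ethyl in place of nitro on an aromatic carbon. For the measured compounds named here, with no measured step to build on, the expected step of a number no higher from compound 2 to compound 3 (the limit leaves the size open) is none beyond the usual scatter. Compound 3 is therefore estimated at 100000 nM, within a range from 30000 nM to 300000 nM, and the likeliest outcome is that it, too, is reported only as a limit.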

Compound 3, half-maximal inhibitory concentration in the HepG2 assay: 84700 nM
Compound 3: middle estimate off by 1.2-fold (0.07 log units), on the high side; low and high end bracket the measured number.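

In the HepG2 assay compound 2 sits at a limit, > 100000 nM, and not at a number. In the HepG2 assay, ethyl in place of nitro, on an aromatic carbon para to a large group, gives an at least 1.1-fold lower number from compound 2 to compound 3 (0.07 log units; that floor lies within the scatter), so this place can carry a group that yields a single number, although the true size of the step stays unsettled. In a physicochemical assay for lipophilicity, measured as octanol-water partition (on this read-out lower numbers stand for lower lipophilicity and higher numbers for higher lipophilicity), compound 2 gives 5.32 and compound 3 gives 6.34 and the same change has a clear effect on lipophilicity: the measured partition coefficient of compound 2, 5.32, and of compound 3, 6.34, a number 1.02 log units higher (beyond the scatter)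

A single pair cannot tell whether the higher partition coefficient and the number in the HepG2 assay are linked. The compounds shown also leave open how an amine, a carboxylic acid or a longer chain at this place would read in the HepG2 assay.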